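Dropping a Methyl: What to Expect for Compound 3

The source may hold more compounds than are shown below. What is called first, only, known or untested is meant among the compounds shown, and "the series" means these compounds.

Measured so far:
- compound 1 `O=C1NC(=O)C(Cc2ccc(Oc3ncc(C(F)(F)F)cc3Cl)cc2)S1`: 69 nM
- compound 2 `Cc1cc(Oc2ccc(C(F)(F)F)cc2Cl)ccc1CC1SC(=O)NC1=O`: 18 nM

Both compounds were tested in a functional assay for agonist activity at Free fatty acid receptor 1 (Homo sapiens), read by FLIPR, in the presence of a further agent that is not named here; a lower number here means that less compound is needed, a higher number that more compound is needed for the effect. Compound 1 gives 69 nM there, and compound 2 gives 18 nM. Of the two numbers, compound 2 has the lower one, and the gap to compound 1 lies beyond the usual scatter; the two compounds differ in more than one place, so nothing can be said about which part of that difference matters.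

Compound 3 `O=C1NC(=O)C(Cc2ccc(Oc3ccc(C(F)(F)F)cc3Cl)cc2)S1` differs from compound 2 in a single place: hydrogen in place of methyl on an aromatic carbon. Put simply, the methyl group that sits ortho to the (2,4-dioxo-1,3-thiazolidin-5-yl)methyl group is taken away and replaced by a hydrogen atom, and everything else stays the same.

Within the data shown here, no measured pair shows what this exact change does. Without such a comparison, the guess is a modest loss, so the expected step from compound 2 to compound 3 is a 2.2-fold higher number from compound 2 to compound 3 (0.35 log units; beyond the scatter). Compound 3 is therefore estimated at 40 nM in this assay, with a range from 15 nM to 110 nM.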

Compound 3, half-maximal effective concentration: 78 nM
For compound 3 the middle estimate is 2.0-fold (0.29 log units) below the measured one, within the range that was stated.
By their numbers in this assay, from the lowest: compound 2; then compounds 1 and 3 (each within the scatter of the next).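

In this assay, among these compounds, taking the methyl away gives a 4.3-fold higher number from compound 2 to compound 3 (0.64 log units; beyond the scatter), a step beyond the usual scatter and the first comparison here in which only one thing changes. It shows that a single carbon atom at this position, ortho to the (2,4-dioxo-1,3-thiazolidin-5-yl)methyl group, is enough to change the read-out measurably, with the methyl-bearing compound 2 needing less compound for the effect than compound 3. Nothing available explains this step, so the result records what the change does but gives no reason for it.

On these data alone, only methyl and hydrogen can be compared at this position, so it remains open whether an ethyl group, a chlorine atom or a methoxy group there would give a lower or a higher number than the methyl. As far as these compounds go, it also remains open whether adding the same methyl to compound 1 would give a step of similar size, or whether its effect holds only in the setting of compound 2.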